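Compound 4: carbamoyl replacing (methylamino)methyl on the core

The source may hold more compounds than are shown below. What is called first, only, known or untested is meant among the compounds shown, and "the series" means these compounds.

Going by the values given here, compound 1 `CNCc1ccc2c(c1)nc(Cn1c(=O)n(C(C)C)c3ccccc31)n2CCC(C)C` gives 1480 nM in an ADME assay on HEp-2 cells (Homo sapiens) for cytotoxicity (on this read-out higher numbers stand for lower toxicity in this test and lower numbers for higher toxicity in this test), the lowest of the three numbers measured so far. Compound 2 `C=C(C)n1c(=O)n(Cc2nc3cc(C(=N)N)ccc3n2CCC(C)C)c2ccccc21` gives 10800 nM and compound 3 `CC(C)CCn1c(Cn2c(=O)n(CC(=O)O)c3ccccc32)nc2cc(C(=N)N)ccc21` gives 173000 nM in this assay. Among the compounds with values here, the only single-point step recorded is a 16-fold higher number from compound 2 to compound 3 (1.20 log units; beyond the scatter). Compound 4 `CC(C)CCn1c(Cn2c(=O)n(C(C)C)c3ccccc32)nc2cc(C(N)=O)ccc21` differs from compound 1 by carbamoyl in place of (methylamino)methyl on an aromatic carbon. Within the data shown here, the change from compound 2 to compound 3 sits on an aromatic nitrogen, not on the aromatic carbon altered here, so it does not bear on this step, and no measured pair shows carbamoyl against (methylamino)methyl. The step is therefore expected to be a 2.7-fold higher number from compound 1 to compound 4 (0.43 log units; beyond the scatter), modest and uncertain in direction. For compound 4 an estimate of 4000 nM is expected, within 1200 nM to 15000 nM.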

Compound 4, half-maximal cytotoxic concentration: 23400 nM
Estimate against measurement, compound 4: 5.9-fold (0.77 log units) below, and the stated range ends below it.
By their numbers in this assay, from the lowest: compound 1; then compound 2; then compound 4; then compound 3.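

In this assay the aromatic carbon of the core proves sensitive to this exchange: carbamoyl in place of (methylamino)methyl gives a large step (a 16-fold higher number from compound 1 to compound 4 (1.20 log units; beyond the scatter)). The two groups match in heavy-atom, hydrogen-bond donor and hydrogen-bond acceptor counts, so these counts do not separate them. No measured property accounts for the step.

As far as these compounds go, it remains open whether the step follows from gaining carbamoyl or from losing (methylamino)methyl. A nitrile or an aminomethyl group on this aromatic carbon would help separate the two.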